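The compounds below may be only part of what the source reports. "The series", "measured", "known", "first", "only" and "open" are said of these compounds alone.

Measured compounds:
compound 1 `CCN(CC)S(=O)(=O)c1ccc(S(=O)(=O)N2CCC[C@@H](C(=O)NC3CN(C(=O)OC(C)(C)C)C3)C2)cc1`, giving 200 nM in a functional assay on MIA PaCa-2 cells (Homo sapiens) for inhibition, read by MTT assay, with a stated time of 7 days; on this read-out lower numbers stand for stronger inhibition and higher numbers for weaker inhibition
compound 2 `CCOC(=O)[C@@H]1CCCN(S(=N)(=O)c2ccc(S(=O)(=O)N(CC)CC)cc2)C1`, giving 12100 nM in this assay

Compound 1 holds the lowest of the two numbers; compound 2 lies far above it, a gap beyond the usual scatter. Compound 3 `CCN(CC)S(=O)(=O)c1ccc(S(=O)(=O)N2CCC[C@@H](C(=O)NC3CN(S(C)(=O)=O)C3)C2)cc1` has not been measured yet. It differs from compound 1 in one place: methylsulfonyl in place of tert-butoxycarbonyl on an amine nitrogen in a ring. Within the data shown here, no measured pair shows what this change does. In this assay the step from compound 1 to compound 3 is expected to be small, in either direction or none beyond the scatter, since compound 1 with 200 nM is the only near anchor. Compound 3 is therefore estimated at 300 nM, within 80 nM to 1200 nM, a step of a 1.5-fold higher number from compound 1 to compound 3 (0.18 log units; within the scatter).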

Compound 3, half-maximal inhibitory concentration: 2500 nM
Beside the measured number, compound 3's estimate is 8.3-fold (0.92 log units) below it, and the stated range ends below it.
By their numbers in this assay, from the lowest: compound 1; then compound 3; then compound 2.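

In this assay, replacing tert-butoxycarbonyl with methylsulfonyl on the amine nitrogen of the four-membered ring gives a 13-fold higher number from compound 1 to compound 3 (1.10 log units; beyond the scatter). The group on this nitrogen therefore strongly affects the read-out, even though the rest of the molecule stays the same. Nothing available here explains this large step.

On these data alone, it remains open how other groups on this nitrogen, such as an acetyl group, a benzyl group or a free amine, would compare. As far as these compounds go, whether any of them could match or improve on compound 1 also remains unknown.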